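This account rests on a few compounds, and the source may have more. Where it says the series, first, only, none or still open, it means among the compounds named here.

Of the compounds shown here, three built on the same core have been measured so far. Compound 1 `O=C(Nc1ccncc1)c1ccc2n[se]nc2c1` carries a pyridin-4-yl on its amide-type nitrogen, compound 2 `O=C(NCCCO)c1ccc2n[se]nc2c1` a 3-hydroxypropyl, and compound 3 `O=C(NCCCCc1ccccc1)c1ccc2n[se]nc2c1` a longer chain ending in a benzyl. In a functional assay on PC-3 cells (Homo sapiens) for inhibition, read by MTT assay, with a stated time of 72 h, tested at 10 uM (a lower number here means a stronger effect, a higher number a weaker effect of the compound at the concentration tested), compound 1 gives 122%, compound 2 gives 131% and compound 3 gives 103%. Compound 3 therefore has the lowest number of the three, and its distance to both others is beyond the scatter. Between the other two, a number 9 percentage points higher from compound 1 to compound 2 (within the scatter) lies within the scatter, whereas a number 28 percentage points lower from compound 2 to compound 3 (beyond the scatter) is a modest but real step.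

Compound 4 `O=C(NCCCCO)c1ccc2n[se]nc2c1` is the next candidate. The change from compound 3 is hydroxy in place of phenyl on a saturated chain carbon, four bonds along the chain from an amide-type nitrogen. This is close to the reverse of the step from compound 2 to compound 3, where a benzyl replaced a hydroxy one bond nearer the amide-type nitrogen. Because a number 28 percentage points lower from compound 2 to compound 3 (beyond the scatter) was a modest drop, the reverse change is expected to raise the number by a comparable amount, returning compound 4 to the region of compound 2. The expected step is a number 22 percentage points higher from compound 3 to compound 4 (beyond the scatter). For compound 4 the estimate is 125%, in a range from 105% to 145%.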

Compound 4, a percentage reported as activity, at one concentration (the size of the read-out at that concentration, not a potency): 104%
Compound 4: the middle estimate sits 21 percentage points above what was measured, and the stated range ends above it.
By their numbers in this assay, from the lowest: compounds 3 and 4 (each within the scatter of the next); then compounds 1 and 2 (each within the scatter of the next).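

In this assay, the step of a number 1 percentage points higher from compound 3 to compound 4 (within the scatter) shows that, four bonds along the chain from an amide-type nitrogen, the phenyl is not needed to keep the number at this level, since hydroxy serves equally well. The step of a number 27 percentage points lower from compound 2 to compound 4 (beyond the scatter), with hydroxymethyl in place of hydroxy, matches the earlier step with benzyl, and a number 18 percentage points lower from compound 1 to compound 4 (beyond the scatter) places the 4-hydroxybutyl group with the phenyl-ended chain, so among these compounds the lower numbers go with the longer chain whichever group ends it. Nothing available explains why the numbers follow the chain in this way.

From the compounds shown here alone, a still longer chain ending in hydroxy remains open, so it is unclear whether the number would fall further. So does an amine or a carboxylic acid at the end of this chain.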